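Adding a second methyl to the amide of compound 3

The source may report more compounds than this note shows. Statements on the series, on what has been measured and on what is new or still open speak of the compounds shown alone.

Compound 1 `CN(c1ncco1)c1cnc(NCc2c(F)ccc3c2CCO3)n2cnnc12`: 21 nM
Compound 2 `Cc1ncccc1-c1cnc(NCc2c(F)ccc3c2CCO3)c2cn[nH]c(=O)c12`: 37 nM
Compound 3 `CNC(=O)c1ccc(-c2cnc(NCc3c(F)ccc4c3CCO4)c3cn[nH]c(=O)c23)c(C)n1`: 13 nM

All three compounds were tested in a functional assay on KARPAS-422 cells (Homo sapiens) for inhibition, read by luminescence and CellTiter-Glo, with a stated time of 14 days; on this read-out lower numbers stand for stronger inhibition of growth and higher numbers for weaker inhibition of growth. Compound 3 gives 13 nM, which lies within the usual scatter of compound 1 but clearly under compound 2. Compound 4 `Cc1nc(C(=O)N(C)C)ccc1-c1cnc(NCc2c(F)ccc3c2CCO3)c2cn[nH]c(=O)c12` has not yet been measured. It differs from compound 3 by methyl in place of hydrogen on an amide-type nitrogen, so methylcarbamoyl becomes dimethylcarbamoyl.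

Going by the values given here, only one measured step bears on this change. The introduction of the methylcarbamoyl group gave a 2.8-fold lower number from compound 2 to compound 3 (0.45 log units; beyond the scatter). Among the compounds with values here, that step shows that the group can matter, but no measured pair varies the amide nitrogen itself. No step beyond the scatter is therefore expected, with a slight lean towards a higher number. The expected change is a 1.4-fold higher number from compound 3 to compound 4 (0.14 log units; within the scatter). For compound 4 the estimate is 18 nM, with an expected range of 7 nM to 45 nM.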

Compound 4, concentration for 50% growth inhibition: 35 nM
Compound 4: middle estimate off by 1.9-fold (0.29 log units), on the low side, and the stated range covers the measured number.
By their numbers in this assay, from the lowest: compounds 3, 1, 4 and 2 (each within the scatter of the next, the first and the last beyond it).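

In this assay, going by these compounds alone, the amide nitrogen proved sensitive to substitution: methyl in place of the amide hydrogen gave a 2.7-fold higher number from compound 3 to compound 4 (0.43 log units; beyond the scatter), the first measured change at this nitrogen. The gain seen with methylcarbamoyl did not survive as dimethylcarbamoyl, since the comparison with hydrogen on the aromatic carbon gave a 1.1-fold lower number from compound 2 to compound 4 (0.02 log units; within the scatter), so the amide hydrogen of the methylcarbamoyl group, not merely the presence of a carbonyl group at this place, goes with the lower number in this pair. Nothing among the data shown accounts for this difference.

The compounds shown leave open how the primary carboxamide, with hydrogen on the nitrogen in place of both methyls, or the ethyl amide would compare. They also leave open whether a carboxylic acid at this place would keep the lower number.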